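A few compounds are considered here, and "the series" means these few. Any claim that something is new, unique, unknown or untested is made for them only; others in the source may bear on it.

Measured so far:
- compound 1 `CCCCc1cn(C(c2ccccc2)c2cc3cc(Br)ccc3nc2OC)nn1`: -3.47%
- compound 2 `CCCCCCCc1cn(C(c2ccccc2)c2cc3cc(Br)ccc3nc2OC)nn1`: 0.17%

In an ADME assay on HEK293 cells (Homo sapiens) for cytotoxicity, read by sulforhodamine B assay, with a stated time of 48 h, tested at 10 uM (on this read-out higher numbers stand for more inhibition at the one concentration tested (going by the name of the read-out) and lower numbers for less inhibition), compound 1 gives -3.47% and compound 2 gives 0.17%; the two sit within the scatter of each other, and the step of a number 3.6 percentage points higher from compound 1 to compound 2 (within the scatter) shows no effect of the added propyl. Compound 3 `COc1nc2ccc(Br)cc2cc1C(c1ccccc1)n1cc(-c2cccc(F)c2)nn1` is not yet measured. The change from compound 1 is 3-fluorophenyl in place of butyl on an aromatic carbon. Within the data shown here, no measured step concerns an aromatic ring in this position, so the one step available bears only loosely on it. With both measured compounds close to the no-effect mark, the expected step is a number 5.5 percentage points higher from compound 1 to compound 3 (within the scatter), none beyond the scatter. Compound 3 is estimated at 2%, in the range -10% to 15%.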

Compound 3, a percentage reported as inhibition, at one concentration (the size of the read-out at that concentration, not a potency): 6.84%
Beside the measured number, compound 3's estimate is 4.8 percentage points below it; the measured number falls inside the stated range.
By their numbers in this assay, from the lowest: compounds 1, 2 and 3 (each within the scatter of the next, the first and the last beyond it).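

In this assay, among these compounds, 3-fluorophenyl in place of butyl gives the first step at this position beyond the scatter, though only a modest one (a number 10.3 percentage points higher from compound 1 to compound 3 (beyond the scatter)). Among the compounds shown here, in place of heptyl, the same group gives a step that stays within the scatter (a number 6.7 percentage points higher from compound 2 to compound 3 (within the scatter)), so the separation from the chain compounds holds for only one of the two pairs. Nothing measured here explains this difference.

Whether the fluorine contributes remains open, since the series shown has no unsubstituted phenyl for comparison. Also open, as far as these compounds go, is how an amine or a carboxylic acid on this aromatic carbon would read.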